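The source may hold more compounds than are shown below. What is called first, only, known or untested is meant among the compounds shown, and "the series" means these compounds.

Measured in a physicochemical assay for lipophilicity, at pH 7.4; on this read-out lower numbers stand for lower lipophilicity and higher numbers for higher lipophilicity:
Compound 1 `N#Cc1ccc(O[C@H]2CN(S(=O)(=O)c3ccc(C(F)(F)F)cc3)C[C@@]2(O)CO)cc1F`: 4.5
Compound 2 `N#Cc1ccc(O[C@H]2CN(S(=O)(=O)c3ccc(Cl)cc3Cl)C[C@]2(O)CO)cc1F`: 4.9

Of these two numbers, compound 1 holds the lower, and compound 2 lies higher by more than the usual scatter. Compound 3 `N#Cc1ccc(O[C@H]2CN(S(=O)(=O)c3ccc(Cl)cn3)C[C@@]2(O)CO)cc1F` keeps the rest of compound 1 but carries 5-chloropyridin-2-yl in place of 4-(trifluoromethyl)phenyl on a sulfonyl sulfur. Within the data shown here, no measured pair shows this exchange, so the expectation rests on the structural change alone and remains rough. A downward move beyond the scatter is expected, estimated as a number 0.70 log units lower from compound 1 to compound 3 (beyond the scatter). For compound 3 the expected value is 3.8, with an estimated range of 3.4 to 4.2.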

Compound 3, distribution coefficient: 3.4
Compound 3: middle estimate off by 0.40 log units, on the high side; the measured number falls inside the stated range.
By their numbers in this assay, from the lowest: compound 3; then compound 1; then compound 2.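

In this assay, replacing 4-(trifluoromethyl)phenyl with 5-chloropyridin-2-yl on the sulfonyl sulfur gives a large step, a number 1.10 log units lower from compound 1 to compound 3 (beyond the scatter). Among these compounds, this is the first single-place comparison, and it shows that this exchange alone can move the read-out well beyond the scatter. Nothing shown accounts for the size of this step.

From the compounds shown here alone, the exchange alters the ring atoms and the substituent together, so their separate shares remain open. A chlorophenyl or a trifluoromethylpyridinyl group at this sulfur would be needed to separate them.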